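Lengthening a Methoxycarbonyl Group: An Expectation for Compound 4

This account rests on a few compounds, and the source may have more. Where it says the series, first, only, none or still open, it means among the compounds named here.

Measured in a functional assay on CHO-K1 cells for agonist activity at Glucose-dependent insulinotropic receptor (Homo sapiens), read by cAMP accumulation and immunoassay, with a stated time of 1 h; on this read-out lower numbers stand for an effect already at smaller amounts and higher numbers for an effect only at larger amounts of compound:
Compound 1 `COC(=O)N1CCC(Oc2cc(Oc3ccc(/C=C4\SC(=O)NC4=O)cc3)ncn2)CC1`: "not active" (no number reported)
Compound 2 `CCOC(=O)N1CCC(Oc2cc(Oc3ccc(/C=C4\SC(=O)NC4=O)cc3)ncn2)CC1`: 790 nM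
Compound 3 `COC(=O)N1CCC(Oc2ncnc(Oc3cccc(/C=C4\SC(=O)NC4=O)c3)c2C)CC1`: "not active" (no number reported)

Compound 3 stands without a number; in this assay compound 3 is reported as "not active" (no number reported), as is compound 1. Among the three, only compound 2 gives a number, 790 nM in this assay. Compound 4 `Cc1c(Oc2cccc(/C=C3\SC(=O)NC3=O)c2)ncnc1OC1CCN(C(=O)OCC(C)C)CC1` has not been measured. It differs from compound 3 by isopropyl in place of hydrogen on a saturated chain carbon bound to an oxygen next to a carbonyl group, a change from methoxycarbonyl to isobutoxycarbonyl. Within the data shown here, no measured pair shows this exact change, so the size of the step in this assay is open; because compound 3 has no number, no direction can be fixed beyond expecting a measurable value to appear. Compound 4 is estimated at 1200 nM, between 200 nM and 8000 nM.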

Compound 4, half-maximal effective concentration: "not active" (no number reported)
Compound 4: no number reported, so the estimate cannot be set against anything.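

Compound 3 and compound 4 both lack a number, so no step between them can be read, and nothing shown offers an explanation for this result. Still open, as far as these compounds go, is whether any other chain on the core of compound 3 would give a measurable value.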